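Trimming an Isopropyl End from the Amide Side Chain

The compounds below may be only part of what the source reports. "The series", "measured", "known", "first", "only" and "open" are said of these compounds alone.

Of the compounds shown here, three sharing one core have been tested in a functional assay on the whole organism with Mus musculus as the target, in the maximal electroshock model, with a stated time of 3 h; a lower number here means that less compound is needed, a higher number that more compound is needed for the effect. Compound 1 `CC1C(=O)NC(c2ccc(N)cc2)c2ccccc21` gives 26 mg/kg. Compound 2 `CC1(C)C(=O)NC(c2ccc(N)cc2)c2ccccc21` gives 20 mg/kg, and the step of a 1.3-fold lower number from compound 1 to compound 2 (0.11 log units; within the scatter) adds a methyl on a saturated ring carbon. Compound 3 `CC(C)NCC(=O)Nc1ccc(C2NC(=O)C(C)(C)c3ccccc32)cc1` gives 27 mg/kg, reached through the step of a 1.4-fold higher number from compound 2 to compound 3 (0.13 log units; within the scatter), which builds a whole side chain onto the aromatic amine. Compound 3 has the highest of the three numbers, yet all three sit within the scatter of one another, so no ranking can be read from them.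

Compound 4 `CC1(C)C(=O)NC(c2ccc(NC(=O)CN)cc2)c2ccccc21` has not yet been measured. It differs from compound 3 by hydrogen in place of isopropyl on an amine nitrogen: the side chain stays, but its isopropyl end is cut away. Within the data shown here, no measured step touches this amine nitrogen directly. Among the measured compounds shown here, the only step reaching the side chain, a 1.4-fold higher number from compound 2 to compound 3 (0.13 log units; within the scatter), attached the entire chain including the isopropyl without moving the number beyond the scatter, which gives no sign that the isopropyl end carries weight. A change within the scatter, in no set direction, is therefore expected, meaning a step of no change at the digits printed from compound 3 to compound 4 (within the scatter). For compound 4 the estimated value in this assay is 27 mg/kg, with a range from 13 mg/kg to 55 mg/kg.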

Compound 4, dose for half-maximal effect: 32.5 mg/kg
Beside the measured number, compound 4's estimate is 1.2-fold (0.08 log units) below it, within the range that was stated.
By their numbers in this assay, from the lowest: compounds 2, 1, 3 and 4 (each within the scatter of the next).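

In this assay, among these compounds, this is the first step that touches the amine nitrogen of the side chain on its own: hydrogen in place of isopropyl gives a 1.2-fold higher number from compound 3 to compound 4 (0.08 log units; within the scatter) and so shows that the isopropyl end can be removed without the number leaving the scatter. The trimmed chain can also be set against the free aromatic amine, where (aminomethyl)carbonyl in place of hydrogen on a nitrogen on an aromatic ring gives a 1.6-fold higher number from compound 2 to compound 4 (0.21 log units; within the scatter) and again stays within the scatter, so this assay does not separate the free amine, the chain with its isopropyl end and the chain without it. With these two steps, the side chain has now been read both with and without its isopropyl end, yet nothing at hand explains why the numbers stay so close.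

The compounds shown leave open whether a benzyl or cyclohexyl group on this amine nitrogen would take the number beyond the scatter. They also leave open whether a longer chain in place of aminomethyl, or a carboxylic acid at its end, would do so.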